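The source may report more compounds than this note shows. Statements on the series, on what has been measured and on what is new or still open speak of the compounds shown alone.

Of the compounds shown here, three have so far been measured in an ADME assay on a cell-free system (plasma, Homo sapiens) for metabolic stability; a higher number here means that the compound lasts longer, a lower number that the compound disappears faster. Compound 1 `COc1ccc2cc([C@H](C)C(=O)OCN(C)C(=O)c3ccccc3)ccc2c1` gives 1.2 h in this assay. Compound 2 `NCCCC[C@H](N)C(=O)OC[C@H]1O[C@@H](n2cc(F)c(=O)[nH]c2=O)C[C@@H]1O` gives 0.647 h, a number so close to that of compound 1 that the two cannot be told apart within the usual scatter of repeated measurements. Compound 3 `CCCC(CCC)C(=O)OCN(CC(=O)OCC)C(=O)c1ccccc1` gives 22 h, a number that lies far above that of compound 1, well beyond the scatter. Compound 1 therefore sits together with compound 2 and a long way beneath compound 3.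

Compound 4 `CCOC(=O)CN(COC(=O)[C@@H](C)c1ccc2cc(OC)ccc2c1)C(=O)c1ccccc1` has not yet been measured. It differs from compound 1 in one place: ethoxycarbonyl in place of hydrogen on a saturated chain carbon bound to an amide-type nitrogen. The group that enters is an ester carrying two hydrogen-bond acceptors and no donor, and it adds no charge.

Within the data shown here, no measured pair shows exactly this change, so the expectation rests on the three numbers alone. Compound 3 also carries an (ethoxycarbonyl)methyl group on a saturated chain carbon bound to an amide-type nitrogen. Because compound 3 gives 22 h in this assay, the step is expected to go upward and beyond the scatter, as a 4.2-fold higher number from compound 1 to compound 4 (0.62 log units; beyond the scatter). Compound 4 is accordingly expected to give about 5 h in this assay, with a range from 1.5 h to 18 h.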

Compound 4, half-life: 1.3 h
Beside the measured number, compound 4's estimate is 3.8-fold (0.59 log units) above it; measured number outside the range, below it.
By their numbers in this assay, from the lowest: compounds 2, 1 and 4 (each within the scatter of the next); then compound 3.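

In this assay, placing ethoxycarbonyl in place of hydrogen on a saturated chain carbon bound to an amide-type nitrogen gives a 1.1-fold higher number from compound 1 to compound 4 (0.03 log units; within the scatter), so this added ester leaves compound 4 indistinguishable from its parent in this measurement. The (ethoxycarbonyl)methyl group stands in compound 4 at 1.3 h as well as in compound 3 at 22 h, so among these compounds, carrying this group does not by itself go with a long half-life. Nothing available explains why the half-life stays within the scatter after this change.

As far as these compounds go, it remains open whether other groups at this place, such as an amine, a carboxylic acid or a longer chain, would also leave the half-life within the scatter of compound 1. The compounds shown also include no partner for compound 3 with hydrogen in place of ethoxycarbonyl, so whether the same change matters in that compound remains unknown.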